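The source may hold more compounds than are shown below. What is called first, only, known or untested is meant among the compounds shown, and "the series" means these compounds.

Measured so far: compound 1, `OCC(O)Cn1nc2c(Br)c(Br)c(Br)c(Br)c2n1`, gives 47% in a functional assay on CCRF-CEM cells (Homo sapiens) for antiproliferative activity, read by MTT assay, with a stated time of 24 h, tested at 50 uM; a lower number here means a stronger effect, a higher number a weaker effect of the compound at the concentration tested; compound 2, `OC(CCn1nc2c(Br)c(Br)c(Br)c(Br)c2n1)c1cccc(Cl)c1`, gives 71%.

Of the two numbers, compound 2 stands highest, with compound 1 lying lower by a margin beyond the usual scatter. Compound 3, `CC(O)CCn1nc2c(Br)c(Br)c(Br)c(Br)c2n1`, differs from compound 2 in one place: methyl in place of 3-chlorophenyl on a saturated chain carbon bound to an oxygen on a saturated carbon and a saturated chain carbon. Going by the values given here, no measured pair shows the effect of this exchange, so the step is uncertain. Since the entering group is a single carbon, compound 3 sits closer in size to compound 1, whose value is 47%, and the step of a number 14 percentage points lower from compound 2 to compound 3 (beyond the scatter) is expected to be a downward one, of modest size. Compound 3 is therefore estimated at 57%, within a range from 38% to 78%.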

Compound 3, a percentage reported as activity, at one concentration (the size of the read-out at that concentration, not a potency): 89%
The estimate for compound 3 lay 32 percentage points below the measured number; measured number outside the range, above it.
By their numbers in this assay, from the lowest: compound 1; then compound 2; then compound 3.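

In this assay, methyl in place of 3-chlorophenyl on this carbon gives a number 18 percentage points higher from compound 2 to compound 3 (beyond the scatter), so the smaller group weakens the effect rather than bringing the number closer to that of compound 1. 2-Hydroxypropyl in place of 1,2-dihydroxyethyl on a saturated chain carbon bound to an aromatic nitrogen gives a number 42 percentage points higher from compound 1 to compound 3 (beyond the scatter), which makes compound 3 the weakest of these compounds. No measurement offered here explains either step. Still open, from the compounds shown here alone, is whether an unsubstituted phenyl would behave like 3-chlorophenyl on this carbon, and how an amine or a carboxylic acid in that place would read.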